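Ester Variation and Plasma Half-Life: Compound 3

The compounds below may be only part of what the source reports. "The series", "measured", "known", "first", "only" and "open" are said of these compounds alone.

Compound 1 `NCc1ccc(C(=O)Nc2ccncc2F)cc1-c1cccc(C(=O)Oc2ccccc2)c1`: 0.117 h
Compound 2 `NCc1ccc(C(=O)Nc2ccncc2F)cc1-c1cccc(C(=O)OCC2CCCO2)c1`: < 0.0834 h

In an ADME assay on a cell-free system (plasma, Homo sapiens) for metabolic stability, read by LC-MS (on this read-out lower numbers stand for a shorter-lived compound and higher numbers for a longer-lived compound), compound 1 gives 0.117 h. Compound 2 reaches only a limit of this assay, < 0.0834 h (the limit of < 0.0834 h in this assay, at which 1 of the 2 values shown sits), so its number is not known. Compound 3 `NCc1ccc(C(=O)Nc2ccncc2F)cc1-c1cccc(C(=O)OC2CCCOC2)c1` differs from compound 2 by oxan-3-yl in place of (oxolan-2-yl)methyl on an oxygen next to a carbonyl group. Among the compounds with values here, the one measured step at the same place, an at least 1.4-fold lower number from compound 1 to compound 2 (0.14 log units; that floor lies within the scatter), has its floor within the scatter. For the change from compound 2 to compound 3 no step beyond the scatter is therefore expected, a step that the limit leaves unreadable from compound 2 to compound 3. Compound 3 is estimated at 0.06 h in this assay, between 0.02 h and 0.15 h.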

Compound 3, half-life: 0.3 h
Compound 3: middle estimate off by 5.0-fold (0.70 log units), on the low side; the measured number lies above the stated range.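

In this assay, the place on an oxygen next to a carbonyl group can move the half-life beyond the scatter, even between two groups with the same atoms: oxan-3-yl in place of (oxolan-2-yl)methyl gives an at least 3.5-fold higher number from compound 2 to compound 3 (0.55 log units; beyond the scatter). Oxan-3-yl in place of phenyl gives a 2.6-fold higher number from compound 1 to compound 3 (0.41 log units; beyond the scatter). The value of compound 2 is a limit, so its step is only a floor: the limit of < 0.0834 h in this assay, at which 1 of the 3 values shown sits.

The compounds shown do not tell whether the oxan ring itself or the absence of the methyl link carries the step. Nor do they show how oxan-4-yl or a plain ethyl group would read at this place.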